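Switching the furan attachment in a dihydropyrimidinone series

The source may hold more compounds than are shown below. What is called first, only, known or untested is meant among the compounds shown, and "the series" means these compounds.

This account concerns a small set of compounds sharing one core and tested in an assay on membranes from HeLa cells for displacement of a labelled ligand from adenosine receptor A3 (Homo sapiens), read by scintillation counting, with a stated time of 180 min, tested at 1 uM; on this read-out higher numbers stand for more inhibition at the one concentration tested (going by the name of the read-out) and lower numbers for less inhibition. Compound 1 `CCCOC(=O)C1=C(C)NC(=O)NC1c1ccoc1` gives 11%, compound 2 `CC1=C(C(=O)OC(C)(C)C)C(c2ccoc2)NC(=O)N1` gives 2%, and compound 3 `CCN(CC)C(=O)C1=C(C)NC(=O)NC1c1ccco1` gives 19%. Compound 3 stands highest of the three numbers: its nearest neighbour is compound 1, lower by an amount within the scatter, while compound 2 lies farthest, lower by an amount beyond the scatter.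

For the measured compounds named here, the one step between compounds that differ in a single place, tert-butyl in place of propyl on an oxygen next to a carbonyl group, is a number 9 percentage points lower from compound 1 to compound 2 (within the scatter), a shift within the scatter.

Compound 4 `CCN(CC)C(=O)C1=C(C)NC(=O)NC1c1ccoc1` differs from compound 3 in one place: furan-3-yl in place of furan-2-yl on a saturated ring carbon. Going by the values given here, no measured step concerns this particular change, since compounds 1 and 2 differ from compound 3 in more than one place, and the only measured step touches the ester alkyl rather than the furan. Compound 1, which carries furan-3-yl, shows a number within the scatter of compound 3.

Among the compounds with values here, with no step bearing directly on the change, compound 4 is expected to show a step of a number 5 percentage points lower from compound 3 to compound 4 (within the scatter) in this assay, that is, none beyond the scatter. Compound 4 is therefore estimated at 14%, with a range from 2% to 28%.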

Compound 4, a percentage reported as inhibition, at one concentration (the size of the read-out at that concentration, not a potency): 37%
For compound 4 the middle estimate is 23 percentage points below the measured one; the measured number lies above the stated range.
By their numbers in this assay, from the lowest: compounds 2, 1 and 3 (each within the scatter of the next, the first and the last beyond it); then compound 4.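

In this assay, furan-3-yl in place of furan-2-yl on a saturated ring carbon gives a number 18 percentage points higher from compound 3 to compound 4 (beyond the scatter) with the diethylamino group held constant, so the point of attachment of the furan matters at this position even though the two groups have the same atoms and the same counts. For the compounds shown here, with furan-3-yl held constant, diethylamino in place of propoxy on a carbonyl carbon gives a number 26 percentage points higher from compound 1 to compound 4 (beyond the scatter) and diethylamino in place of tert-butoxy gives a number 35 percentage points higher from compound 2 to compound 4 (beyond the scatter), which shows that the group on the carbonyl carbon also matters, whereas the one earlier step, between the two esters, was a number 9 percentage points lower from compound 1 to compound 2 (within the scatter) and stayed within the scatter. Nothing in the material at hand accounts for either shift.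

The compounds shown leave open whether furan-3-yl in place of furan-2-yl would also raise the number with propoxy or tert-butoxy on the carbonyl carbon, since the one comparison of the two furans carries diethylamino. They also leave open how a phenyl ring on the saturated ring carbon, or a piperidine or dimethylamino group on the carbonyl carbon, would read.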